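A few compounds are considered here, and "the series" means these few. Any claim that something is new, unique, unknown or untested is made for them only; others in the source may bear on it.

Measured so far:
compound 1 `CC1(C)C[C@H](O)C[C@](C)(CNc2ccccc2)C1`: 37000 nM in an ADME assay on MDCK cells (Canis lupus familiaris) for cytotoxicity, read by MTT assay, with a stated time of 3 days; a higher number here means that more compound is tolerated, a lower number that less compound is tolerated
compound 2 `CC1(C)C[C@H](O)C[C@](C)(CNc2cccc(S(C)(=O)=O)c2)C1`: > 50000 nM in this assay, a limit of the assay rather than a number

For the measured compounds named here, compound 2 therefore stands only as a limit in this assay; its position relative to compound 1 is known no closer than the single measured step, an at least 1.3-fold higher number from compound 1 to compound 2 (0.13 log units; that floor lies within the scatter), whose floor is set by the limit of > 50000 nM in this assay, at which 1 of the 2 values shown sits, and lies within the scatter.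

Compound 3 `CC1(C)C[C@H](O)C[C@](C)(CNc2cccc(S(N)(=O)=O)c2)C1` differs from compound 2 by amino in place of methyl on a sulfonyl sulfur. Going by the values given here, no measured step touches the sulfonyl sulfur, so the only guidance is the step from hydrogen to methylsulfonyl, which did not move the read-out beyond the scatter. The step from compound 2 to compound 3 is expected to be small, a step that the limit leaves unreadable from compound 2 to compound 3, with the limit likely reached again. For compound 3 the estimate is 60000 nM, within 30000 nM to 120000 nM.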

Compound 3, half-maximal cytotoxic concentration: > 100000 nM
Compound 3 ended at the assay's limit; the forecaster's own chance of this, stated with the estimate: 70%; middle value at least 1.6-fold (0.22 log units) from the limit.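

Sulfamoyl in place of hydrogen on an aromatic carbon gives the first step in this assay that is read as beyond the scatter: an at least 2.7-fold higher number from compound 1 to compound 3 (0.43 log units; beyond the scatter). Compound 3 is held only as a limit of the assay, > 100000 nM, so the size of this step is known only as a floor. The step between compound 2 and compound 3 cannot be read, and amino and methyl on the sulfonyl sulfur stay unranked, with compound 2 and compound 3 each resting on a limit: the limit of > 100000 nM in this assay, at which 1 of the 3 values shown sits.

Left open is where compound 3 lies beyond its limit, and whether amino against methyl on the sulfonyl sulfur changes the read-out at all in this assay. Also open, going by these compounds, is whether a carboxylic acid or an amine in place of hydrogen on the same aromatic ring of the core of compound 1 would likewise separate from compound 1.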